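The compounds below may be only part of what the source reports. "The series", "measured", "known", "first", "only" and "open" are said of these compounds alone.

Measured compounds, growth inhibition:

compound 1 `COc1cc2c(cc1CC=C(C)C)C(=O)C[C@@H](c1ccc(Oc3ccccc3)cc1)O2`: 69%
compound 2 `COc1ccc([C@@H]2C/C(=N/OCc3cn(-c4ccc(C(=O)c5ccccc5)cc4)nn3)c3cc(CC=C(C)C)c(OC)cc3O2)cc1`: 41%
compound 3 `COc1cc2c(cc1CC=C(C)C)C(=O)C[C@@H](c1ccc(Oc3cccc([N+](=O)[O-])c3)cc1)O2`: 53%

In a functional assay on MCF7 cells (Homo sapiens) for inhibition, read by sulforhodamine B assay, with a stated time of 48 h, tested at 50 uM (on this read-out lower numbers stand for less inhibition of growth and higher numbers for more inhibition of growth at the one concentration tested), compound 3 gives 53%, the second highest of the three numbers. Its nearest neighbour is compound 2, which in this assay gives 41%; the furthest is compound 1, which in this assay gives 69%. Compound 2 differs from compound 3 in several places at once, so only the two values themselves can be compared. Compound 1 and compound 3 differ in one place: a number 16 percentage points lower from compound 1 to compound 3 (beyond the scatter).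

Compound 4 `C#CCOc1ccc([C@@H]2CC(=O)c3cc(CC=C(C)C)c(OC)cc3O2)cc1` has not been measured in this assay. It differs from compound 3 as follows: propargyl in place of 3-nitrophenyl on an oxygen on an aromatic ring.

Within the data shown here, only one measured step bears on this change, and only in part. Among the measured compounds shown here, the step of a number 16 percentage points lower from compound 1 to compound 3 (beyond the scatter) shows that the nitro group on the 3-nitrophenyl costs something; compound 4 loses that nitro together with the whole 3-nitrophenyl, but puts propargyl in its place, and no measured pair shows what propargyl does on this oxygen. A modest rise toward the value of compound 1 is therefore expected, with wide uncertainty, as a number 5 percentage points higher from compound 3 to compound 4 (within the scatter). For compound 4 the estimate in this assay is 58%, between 38% and 76%.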

Compound 4, percent growth inhibition at one concentration: 68%
Compound 4: the middle estimate sits 10 percentage points below what was measured; measured number inside the range.
By their numbers in this assay, from the lowest: compound 2; then compound 3; then compounds 4 and 1 (each within the scatter of the next).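

In this assay, propargyl in place of 3-nitrophenyl on an oxygen on an aromatic ring gives a number 15 percentage points higher from compound 3 to compound 4 (beyond the scatter) and propargyl in place of phenyl gives a number 1 percentage points lower from compound 1 to compound 4 (within the scatter) at that same oxygen. The earlier compounds shown here showed only what a nitro group on the terminal phenyl does, while these two steps compare a different kind of group at this oxygen: among compound 1, compound 3 and compound 4, an aromatic ring there is not required for growth inhibition to remain within the scatter of the value of compound 1, and it is the nitro-bearing compound 3 that stands apart from the other two. Nothing measured here explains why the numbers fall this way.

On these data alone, it remains open how this oxygen would respond to a longer chain, an amine or a carboxylic acid in place of propargyl. As far as these compounds go, with readings from one concentration in one cell line, it also remains open whether compound 1 and compound 4 would separate across a range of concentrations or in other cell lines.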